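Working notes: methoxycarbonyl in place of methoxy

The compounds below may be only part of what the source reports. "The series", "measured", "known", "first", "only" and "open" are said of these compounds alone.

Of the compounds shown here, two have numbers so far in a functional assay for inhibition, with Rattus norvegicus as the target; a higher number here means a weaker inhibitor, a lower number a stronger inhibitor. Compound 1 (`CC(/N=c1\c(O)c(O)\c1=N/c1cccnc1)C(C)(C)C`) gives 1950 nM, and compound 2 (`COc1ccc(Nc2c(NC(C)C(C)(C)C)c(=O)c2=O)cc1`) gives 2400 nM. Compound 2 therefore stands within the scatter of compound 1, and the pair sets no order. Compound 3 (`COC(=O)c1ccc(Nc2c(NC(C)C(C)(C)C)c(=O)c2=O)cc1`) carries methoxycarbonyl in place of methoxy on an aromatic carbon, para to a large group: methoxycarbonyl in place of methoxy on an aromatic carbon. Going by the values given here, no measured step covers this change, so the two values offer no direct guide to its size or direction. A moderate move toward a lower number, meaning a stronger inhibitor, is expected, though this expectation is held loosely: a 2.4-fold lower number from compound 2 to compound 3 (0.38 log units; beyond the scatter). Compound 3 is estimated at 1000 nM, with an expected range from 200 nM to 4000 nM.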

Compound 3, half-maximal inhibitory concentration: > 30000 nM
Compound 3: no number, only a limit; the forecaster's own chance of this, stated with the estimate: 5%; middle value at least 30-fold (1.47 log units) from the limit.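

In this assay, going by these compounds alone, the para position of this aromatic ring proves sensitive: methoxycarbonyl in place of methoxy on an aromatic carbon gives an at least 12-fold higher number from compound 2 to compound 3 (1.09 log units; beyond the scatter), the only measured step and one well beyond the scatter. The pair of compounds 1 and 2 set no order, whereas this change separates two compounds that differ in one place and shows that the substituent at this position can decide whether a measurable number is obtained at all. Compound 3 stands at a limit and not at a number, so the full size of the step remains unknown: the limit of > 30000 nM in this assay, at which 1 of the 3 values shown sits.

The compounds shown leave open how a carboxylic acid, a primary amide or a plain methyl would read at the same place. They also leave open whether the loss follows the ester as a whole or could be recovered with a longer alkoxy chain.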